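The compounds below may be only part of what the source reports. "The series", "measured", "known", "first", "only" and "open" are said of these compounds alone.

Compound 1, `O=C(COc1ccc2cc(C(O)(C(F)(F)F)C(F)(F)F)c(O)cc2c1)Nc1nc2ccccc2s1`, gives the lower of the two numbers recorded in an assay on isolated protein for inhibition of tyrosine-protein phosphatase non-receptor type 13 (Homo sapiens), read by spectrophotometry; on this read-out lower numbers stand for stronger inhibition and higher numbers for weaker inhibition; there compound 1 gives 9900 nM. Its nearest measured neighbour is compound 3, `Cc1ccc(O)c(C(O)(C(F)(F)F)C(F)(F)F)c1`, which in this assay gives 454000 nM, a gap well beyond the scatter. Compound 2, `Oc1ccc(-c2ccccc2)cc1C(O)(C(F)(F)F)C(F)(F)F`, reaches only a limit in this assay and is reported as > 500000 nM. For the measured compounds named here, the single step that can be read between measured compounds, an at least 1.1-fold lower number from compound 2 to compound 3 (0.04 log units; that floor lies within the scatter), concerns the substituent on an aromatic carbon and stays within the scatter.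

Compound 4, `O=C(COc1ccc2cc(C(O)(C(F)(F)F)C(F)(F)F)c(O)cc2c1)Nc1cccc2ccccc12`, differs from compound 1 in one place: naphthalen-1-yl in place of 1,3-benzothiazol-2-yl on an amide-type nitrogen. Going by the values given here, no measured pair touches the group on the amide-type nitrogen, so the step from compound 2 to compound 3 cannot be carried over, and the data offer no direct guide for this change. Without such a guide, the expectation is a number close to that of compound 1, with room for a modest drift in either direction. Compound 4 is therefore expected to show a step of a 1.5-fold higher number from compound 1 to compound 4 (0.18 log units; within the scatter), and its estimated value is 15000 nM, with a range from 4000 nM to 60000 nM.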

Compound 4, half-maximal inhibitory concentration: > 20000 nM
Compound 4: a limit, no number; the forecaster's own chance of this, stated with the estimate: 5%; middle value at least 1.3-fold (0.12 log units) away from the limit.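

For the compounds shown here, the group on the amide-type nitrogen is now tied to a reading for the first time, something the earlier pair, which concerned only a substituent on an aromatic carbon, could not provide. In this assay, placing naphthalen-1-yl on that nitrogen gives an at least 2.0-fold higher number from compound 1 to compound 4 (0.30 log units; that floor lies within the scatter), so this exchange brings no gain over 1,3-benzothiazol-2-yl, although the printed floor alone does not establish a loss beyond the scatter. Compound 4 gives a limit and not a number, which bounds the step on one side only: the limit of > 20000 nM in this assay, at which 1 of the 4 values shown sits.

The compounds shown leave open how far compound 4 truly lies from compound 1, and whether any difference would follow the loss of the ring nitrogen and sulfur or the exchange of a five-membered ring for a six-membered one, since this single change alters both at once. They also leave open how a pyridin-2-yl group, or a group carrying a carboxylic acid, would read in this assay on the same amide-type nitrogen.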